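The source may report more compounds than this note shows. Statements on the series, on what has been measured and on what is new or still open speak of the compounds shown alone.

Measured so far:
- compound 1, `Nc1cc(N)c2nc(-c3ccccc3)c(NCc3ccc(Cl)c(Cl)c3)nc2c1`: 6030 nM
- compound 2, `COc1ccc(CNc2nc3cc(N)cc(N)c3nc2-c2ccccc2)cc1OC`: 18200 nM
- compound 3, `Nc1cc(N)c2nc(-c3ccccc3)c(NCc3ccc(F)cc3)nc2c1`: < 100000 nM

All three were tested in a functional assay on SR cells (Homo sapiens) for inhibition, read by sulforhodamine B assay, with a stated time of 48 h; a higher number here means a weaker inhibitor of growth, a lower number a stronger inhibitor of growth. Compound 1 gives 6030 nM in this assay. Compound 2 gives 18200 nM. For compound 3 the assay reports only a limit, < 100000 nM, and not a number; this is the line (the limit of < 100000 nM in this assay, at which 1 of the 3 values shown sits). Compound 3 therefore cannot be placed exactly among the others: the step that the limit leaves unreadable from compound 1 to compound 3 and the step that the limit leaves unreadable from compound 2 to compound 3 are both unreadable.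

Compound 4, `COc1ccc(CNc2nc3cc(N)cc(N)c3nc2-c2ccccc2)cc1`, differs from compound 3 in one place: methoxy in place of fluoro on an aromatic carbon. For the measured compounds named here, the only measured step that touches the same part of the molecule is a 3.0-fold higher number from compound 1 to compound 2 (0.48 log units; beyond the scatter), where methoxy groups entered in place of chlorines on the same benzyl ring. That step was modest and pointed toward a higher number. Since compound 3 stands only at a limit, the expected step that the limit leaves unreadable from compound 3 to compound 4 is an estimate with wide uncertainty. Compound 4 is expected to give about 30000 nM in this assay, within a range of 8000 nM to 100000 nM.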

Compound 4, concentration for total growth inhibition: < 100000 nM
Compound 4: only a limit was reported (the forecaster's own chance of this, stated with the estimate: 35%); the middle value is on the limit's open side.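

Compound 4 gives only a limit in this assay, < 100000 nM. No step from compound 1, compound 2 or compound 3 to compound 4 can be read: the limit of < 100000 nM in this assay, at which 2 of the 4 values shown sit.

As far as these compounds go, whether 4-methoxybenzyl in compound 4 or 4-fluorobenzyl in compound 3 gives the stronger inhibitor of growth stays open.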